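Swapping chlorines for fluorines on the ketone-bound ring

A few compounds are considered here, and "the series" means these few. Any claim that something is new, unique, unknown or untested is made for them only; others in the source may bear on it.

Of the compounds shown here, two built on the same core have been measured in a functional assay on IGROV-1 cells (Homo sapiens) for inhibition, read by sulforhodamine B assay, with a stated time of 48 h; a higher number here means a weaker inhibitor of growth, a lower number a stronger inhibitor of growth. Compound 1 `COc1ccc(-c2cc(/C=C/C(=O)c3ccc(N)cc3)[nH]n2)cc1` gives 2270 nM. Compound 2 `COc1cc(-c2cc(/C=C/C(=O)c3ccc(Cl)c(Cl)c3)[nH]n2)cc(OC)c1OC` gives 24000 nM, the higher of the two numbers, with compound 1 standing at a lower number, a gap beyond the usual scatter. Compound 3 `COc1cc(-c2cc(/C=C/C(=O)c3ccc(F)c(F)c3)[nH]n2)cc(OC)c1OC` differs from compound 2 in one place: 3,4-difluorophenyl in place of 3,4-dichlorophenyl on a carbonyl carbon. Among the measured compounds shown here, no measured pair shows the effect of this change, so only a modest step is expected, in either direction or none beyond the scatter. For compound 3 the expected value in this assay is 30000 nM, within 10000 nM to 90000 nM, an expected step of a 1.3-fold higher number from compound 2 to compound 3 (0.10 log units; within the scatter).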

Compound 3, concentration for 50% growth inhibition: 3620 nM
Estimate against measurement, compound 3: 8.3-fold (0.92 log units) above, outside the stated range (below it).
By their numbers in this assay, from the lowest: compounds 1 and 3 (each within the scatter of the next); then compound 2.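

In this assay putting 3,4-difluorophenyl in place of 3,4-dichlorophenyl on the carbonyl carbon gives a 6.6-fold lower number from compound 2 to compound 3 (0.82 log units; beyond the scatter) on the shared core. This position is therefore sensitive to which halogen the ring carries, and of this pair the difluorophenyl compound is the stronger inhibitor of growth. Nothing measured here explains the difference. Still open, as far as these compounds go, is whether the ring needs halogens at all, and how a plain phenyl or a 3,4-dimethoxyphenyl group would compare in the same place.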